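This account rests on a few compounds, and the source may have more. Where it says the series, first, only, none or still open, it means among the compounds named here.

Working notes on the series.

For the measured compounds named here, compound 2 `COc1ccc(C2=Cc3ccc([N+](=O)[O-])cc3C(CC(C)=O)N2c2ccc(C)cc2)cc1` is the one compound of this set with a number in hand. In an ADME assay on TZM cells (Homo sapiens) for cytotoxicity, read by CellTiter-Glo, with a stated time of 48 h (a lower number here means that less compound is tolerated, a higher number that more compound is tolerated), compound 2 gives 10600 nM. Compound 1 `COc1ccc(C2=Cc3ccc(F)cc3C(CC(C)=O)N2c2ccc(C#N)cc2)cc1` belongs to the same series, but in this assay compound 1 gives "not determined" (no result reported), so compound 2 stands alone on the numbers shown; there is nothing to rank it against.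

Compound 3 `COc1ccc(C2=Cc3ccc([N+](=O)[O-])cc3C(CC(C)=O)N2c2ccc(C#N)cc2)cc1` is the next compound to be run. It differs from compound 2 in one place: cyano in place of methyl on an aromatic carbon. The cyano group it acquires is the same group that compound 1 carries on its own N-aryl ring, but since compound 1 has no result in this assay, that parallel gives no guidance on the size of the step.

Going by the values given here, with no measured step of this kind available, the working expectation is that the change from compound 2 to compound 3 stays within the usual scatter of this assay, with no direction favoured. On that basis compound 3 is estimated at 10000 nM in this assay, with a range from 4000 nM to 25000 nM, which means an expected step of a 1.1-fold lower number from compound 2 to compound 3 (0.03 log units; within the scatter).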

Compound 3, half-maximal cytotoxic concentration: 15400 nM
Compound 3: middle estimate off by 1.5-fold (0.19 log units), on the low side; low and high end bracket the measured number.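

In this assay, for the compounds shown here, the replacement of 4-methylphenyl by 4-cyanophenyl gives the first one-place comparison, and it reads a 1.5-fold higher number from compound 2 to compound 3 (0.16 log units; within the scatter). At this position, para to a large group, methyl and cyano therefore cannot be told apart in this assay, and the triple bond and hydrogen-bond acceptor that cyano brings come with no step beyond the scatter. No supporting measurement bears on this result, so the step stands without an explanation.

The compounds shown leave open whether a quite different group at this position, such as an amine, a carboxylic acid or a longer chain, would give a step beyond the scatter in this assay. From the compounds shown here alone, it is also open whether the same reading holds with fluorine in place of the nitro group on the shared core, since compound 1 gives "not determined" (no result reported) and so offers no comparison with compound 3.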